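Alkylamino chain extension at the fluorobenzyl analogue

A few compounds are considered here, and "the series" means these few. Any claim that something is new, unique, unknown or untested is made for them only; others in the source may bear on it.

Measured so far:
compound 1 `CNc1nc(-c2ccccc2)nc2c1nnn2Cc1ccccc1Cl` – 191000000 nM
compound 2 `FC(F)(F)c1ccccc1Cn1nnc2c(NC3CCCCC3)nc(-c3ccccc3)nc21` – 6800000 nM
compound 3 `CNc1nc(-c2ccccc2)nc2c1nnn2Cc1ccccc1F` – 25000000 nM

In an assay on isolated protein for binding affinity to adenosine receptor A1 (Bos taurus) (on this read-out higher numbers stand for weaker inhibition and lower numbers for stronger inhibition), compound 3 stands second highest of the three numbers; compound 1 sits higher and compound 2 lower. Within the data shown here, the one measured step, a 7.6-fold lower number from compound 1 to compound 3 (0.88 log units; beyond the scatter), concerns a halogen swap and says nothing about the amine side. Compound 4 `CCCCCCNc1nc(-c2ccccc2)nc2c1nnn2Cc1ccccc1F` differs from compound 3 by pentyl in place of hydrogen on a saturated chain carbon bound to a nitrogen on an aromatic ring. Among the measured compounds shown here, no measured step bears on this change. Compound 2, carrying a cyclohexylamino group, gives a lower number than compound 3, but it also differs at the benzyl group, so only the two values can be compared. A lowering step is expected, a 5.0-fold lower number from compound 3 to compound 4 (0.70 log units; beyond the scatter), with wide uncertainty. Compound 4 is therefore estimated at 5000000 nM, range 800000 nM to 30000000 nM.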

Compound 4, inhibition constant: 25000000 nM
Estimate against measurement, compound 4: 5.0-fold (0.70 log units) below, within the range that was stated.
By their numbers in this assay, from the lowest: compound 2; then compounds 3 and 4 (each within the scatter of the next); then compound 1.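

In this assay, methylamino to hexylamino on the fluorobenzyl analogue gives no change at the digits printed from compound 3 to compound 4 (within the scatter). Among these compounds, this is the first one-place comparison on the amine side, and for these two compounds the added pentyl on the saturated chain carbon bound to a nitrogen on an aromatic ring leaves no step that can be told from the scatter. No measured evidence bears on why this is so.

Going by these compounds, whether an intermediate chain such as propylamino would fall in line with these two compounds remains open. Also open, on these data alone, is how a chain ending in a hydroxyl or a carboxylic acid would read at this position.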